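The source may hold more compounds than are shown below. What is called first, only, known or untested is meant among the compounds shown, and "the series" means these compounds.

Working notes on the series. Compound 1 `CNC(=O)[C@@]12C[C@@H]1[C@@H](n1cnc3c(NC)nc(C#Cc4ccccc4)nc31)[C@H](O)[C@@H]2O` and compound 2 `CNC(=O)[C@@]12C[C@@H]1[C@@H](n1cnc3c(NC)nc(C#Cc4ccc(-c5ccccc5)cc4)nc31)[C@H](O)[C@@H]2O` share one core and differ only at the far end of the alkyne. In an assay on CHO cells for displacement of a labelled ligand from adenosine receptor A1 (Homo sapiens), read by scintillation counting, with a stated time of 60 min, tested at 10 uM (on this read-out lower numbers stand for less inhibition and higher numbers for more inhibition at the one concentration tested (going by the name of the read-out)), compound 1 gives 18%, and compound 2 gives 18%. The one measured step, no change at the digits printed from compound 1 to compound 2 (within the scatter), leaves compound 1 level with compound 2 at the digits shown, within the scatter, so compound 1 stands neither above nor below its nearest neighbour.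

Compound 3 `CNC(=O)[C@@]12C[C@@H]1[C@@H](n1cnc3c(NC)nc(C#CC4CC4)nc31)[C@H](O)[C@@H]2O` is reached from compound 1 by cyclopropyl in place of phenyl on a triple-bonded carbon. Within the data shown here, no measured step exchanges the phenyl itself; the only step that touches this end of the molecule, adding a phenyl onto it, gave no change beyond the scatter, and nothing measured speaks for a shift in either direction. For compound 3 the step from compound 1 is therefore expected to be no change at the digits printed from compound 1 to compound 3 (within the scatter), nothing beyond the scatter. Compound 3 is estimated at 18% in this assay, within a range from 5% to 35%.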

Compound 3, a percentage reported as inhibition, at one concentration (the size of the read-out at that concentration, not a potency): 38%
Compound 3: the middle estimate sits 20 percentage points below what was measured, outside the stated range (above it).
By their numbers in this assay, from the lowest: compounds 1 and 2 (each within the scatter of the next); then compound 3.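

The far end of the alkyne is not indifferent in this assay: exchanging the end group moves the number beyond the scatter (a number 20 percentage points higher from compound 1 to compound 3 (beyond the scatter); a number 20 percentage points higher from compound 2 to compound 3 (beyond the scatter)), which the phenyl addition alone (no change at the digits printed from compound 1 to compound 2 (within the scatter)) gave no sign of. Among these three compounds, the two with an aromatic carbon ring at this end stand level, and compound 3, with cyclopropyl, stands higher, so the read-out at this position responds to the kind of end group and does not simply follow its size in heavy atoms. Nothing available bears on the cause of this rise.

From the compounds shown here alone, whether the rise is particular to cyclopropyl or extends to other non-aromatic end groups stays open, for instance a cyclobutyl or cyclohexyl ring, a longer straight alkyl chain, or a chain ending in an amine. The single-concentration read-out also leaves the potency of compound 3 undefined.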